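A few compounds are considered here, and "the series" means these few. Any claim that something is new, unique, unknown or untested is made for them only; others in the source may bear on it.

Measured compounds:
Compound 1 `COc1ccc(-c2cnc3nc(N)nc(OC(C)C)c3n2)cc1OC`, 400 nM
Compound 2 `COc1ccc(-c2cnc3nc(N)nc(N4CCN(c5ccc(C)cc5)CC4)c3n2)cc1OC`, 300 nM
Compound 3 `CCOc1ccc(-c2cnc3nc(N)nc(OC(C)C)c3n2)cc1`, 10000 nM

In a functional assay on cells (T-cell, Homo sapiens) for inhibition (on this read-out higher numbers stand for weaker inhibition and lower numbers for stronger inhibition), compound 2 gives the lowest of the three numbers. The nearest to it is compound 1, whose value in this assay is 400 nM, a gap that lies within the scatter, so the two cannot be ordered. Compound 3, with 10000 nM in this assay, stands well beyond the scatter above compound 2.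

Compound 4 `COc1ccc(-c2cnc3nc(N)nc(N4CCN(C(=O)COc5ccc(Cl)cc5)CC4)c3n2)cc1OC` has not yet been measured in this assay. It differs from compound 2 in a single place: ((4-chlorophenoxy)methyl)carbonyl in place of 4-methylphenyl on an amine nitrogen in a ring. Going by the values given here, no measured pair shows what such a change does on this core, so the size of the step is open. The account expects the step from compound 2 to compound 4 to be small, perhaps a mild weakening, with the estimated step of a 2.0-fold higher number from compound 2 to compound 4 (0.30 log units; within the scatter) in this assay. For compound 4 the expected value in this assay is therefore 600 nM, in an estimated range from 150 nM to 2500 nM.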

Compound 4, half-maximal inhibitory concentration: 0.5 nM
Compound 4: middle estimate off by 1200-fold (3.08 log units), on the high side, and the stated range ends above it.
By their numbers in this assay, from the lowest: compound 4; then compounds 2 and 1 (each within the scatter of the next); then compound 3.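

In this assay, the group on the amine nitrogen of the six-membered ring turns out to matter greatly: ((4-chlorophenoxy)methyl)carbonyl in place of 4-methylphenyl gives a 600-fold lower number from compound 2 to compound 4 (2.78 log units; beyond the scatter). Going by these compounds alone, the entering group differs from the leaving one in its carbonyl, its ether oxygen, its chlorine and its size, so this single change shows only that the whole group brings the step, not which part of it does. Nothing measured here explains the gain.

The compounds shown leave open which of those parts carries the step. An acetyl group, a phenoxyacetyl group without the chlorine, or a longer chain between the carbonyl and the ring oxygen, on the same nitrogen, would begin to separate them.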